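Diaryl urea pyrimidine series: thioether analogue with dichlorophenyl

The source may report more compounds than this note shows. Statements on the series, on what has been measured and on what is new or still open speak of the compounds shown alone.

Two ureas have been run in a functional assay on MGC-803 cells (Homo sapiens) for cytotoxicity, read by MTT assay, with a stated time of 3 days; a lower number here means a stronger inhibitor, a higher number a weaker inhibitor. Compound 1 `Cc1cc(C)nc(Oc2ccc(NC(=O)Nc3ccc(Cl)cc3Cl)cc2)n1` gives 35400 nM. Compound 2 `Cc1cccc(NC(=O)Nc2ccc(Sc3nc(C)cc(C)n3)cc2)c1` gives 25300 nM, the lower of the two numbers shown, though the gap to compound 1 falls inside the usual scatter, so the two values cannot be ordered. Going by the values given here, compounds 1 and 2 differ in two places and no single step links them.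

Compound 3 `Cc1cc(C)nc(Sc2ccc(NC(=O)Nc3ccc(Cl)cc3Cl)cc2)n1` is the next member, carrying the change (2,4-dichlorophenyl in place of 3-methylphenyl on an amide-type nitrogen). Among the compounds with values here, the only guide is that compound 1 and compound 2, which share neither of the two varied parts, sit within scatter of each other; nothing in hand shows a step beyond the scatter from this kind of exchange. The expected step from compound 2 to compound 3 in this assay is therefore a 1.2-fold higher number from compound 2 to compound 3 (0.07 log units; within the scatter), with no direction clearly favoured. Compound 3 is estimated at 30000 nM, within a range of 10000 nM to 90000 nM.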

Compound 3, half-maximal inhibitory concentration: > 50000 nM
Compound 3: no number, only a limit; the forecaster's own chance of this, stated with the estimate: 15%; middle value at least 1.6-fold (0.22 log units) from the limit.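

In this assay compound 3 gives only a limit of the assay, not a number: the limit of > 50000 nM in this assay, at which 1 of the 3 values shown sits. On the amide-type nitrogen, 2,4-dichlorophenyl in place of 3-methylphenyl gives an at least 1.9-fold higher number from compound 2 to compound 3 (0.29 log units; that floor lies within the scatter), and on the aromatic carbon, (4,6-dimethylpyrimidin-2-yl)sulfanyl in place of (4,6-dimethylpyrimidin-2-yl)oxy gives an at least 1.4-fold higher number from compound 1 to compound 3 (0.14 log units; that floor lies within the scatter). Each single change can now be read for the first time, but only as a floor, so neither is shown to shift the value beyond the scatter.

As far as these compounds go, the real size of both steps stays open while compound 3 has no number. Also open, from the compounds shown here alone, is how the series responds to an aminophenyl or carboxyphenyl group on the amide-type nitrogen, or to an amino or methylene link in place of the sulfanyl link.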